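This account rests on a few compounds, and the source may have more. Where it says the series, first, only, none or still open, it means among the compounds named here.

Compound 3 `CCCCNC(=O)Nc1cc2nc(C3CCCCC3)[nH]c2cc1N(C)C` is the starting point of this step. In an ADME assay on Vero cells (Chlorocebus sabaeus) for cytotoxicity, read by resazurin assay, with a stated time of 3 days (on this read-out lower numbers stand for stronger inhibition and higher numbers for weaker inhibition), compound 3 gives > 100 ug/mL, which is a limit of the assay and not a number. Two further compounds in the same assay carry the pyrrolidin-1-yl group that compound 4 takes on. Compound 1 `O=C(Nc1cc2nc(C3CCCCC3)[nH]c2cc1N1CCCC1)c1ccc(Br)cc1` gives > 100 ug/mL in this assay, a limit of the assay. Compound 2 `O=C(Nc1cc2nc(C3CCCCC3)[nH]c2cc1N1CCCC1)OCC(F)(F)F` gives > 100 ug/mL in this assay, again a limit. The one step among these two, a step that the two limits leave unreadable from compound 1 to compound 2, stays unreadable, as both its ends are limits. Thus the limit of > 100 ug/mL in this assay, at which 3 of the 3 values shown sit, sums up everything measured: no numbered value exists on which a change could be sized. Compound 4 `CCCCNC(=O)Nc1cc2nc(C3CCCCC3)[nH]c2cc1N1CCCC1` differs from compound 3 by pyrrolidin-1-yl in place of dimethylamino on an aromatic carbon. Among the compounds with values here, no measured step bears on this change directly, and the two measured carriers of pyrrolidin-1-yl, compound 1 and compound 2, both sit at the limit. For compound 4 the step that the limit leaves unreadable from compound 3 to compound 4 is therefore expected to be none beyond the scatter. The estimate for compound 4 in this assay is 150 ug/mL, with a range from 70 ug/mL to 400 ug/mL, and it is expected that the assay will most likely again report only a limit.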

Compound 4, half-maximal inhibitory concentration: > 100 ug/mL
Compound 4: only a limit was reported; the forecaster's own chance of this, stated with the estimate: 85%; the middle value is on the limit's open side.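

In this assay compound 4 gives > 100 ug/mL, a limit of the assay and not a number. The steps joining compound 4 to compound 1, compound 2 and compound 3 cannot be read, and the picture stays as it was: the limit of > 100 ug/mL in this assay, at which 4 of the 4 values shown sit. The compounds shown leave open whether pyrrolidin-1-yl in place of dimethylamino, or any other change among them, alters the read-out in this assay at all.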